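Adding a methyl to compound 3

The source may report more compounds than this note shows. Statements on the series, on what has been measured and on what is new or still open speak of the compounds shown alone.

Values in a toxicity assay on HepG2 2.2.15 cells (Homo sapiens) for cytotoxicity, read by CellTiter-Glo; on this read-out lower numbers stand for higher toxicity in this test and higher numbers for lower toxicity in this test:
compound 1 `O=C(Nc1cc(F)c(F)c(F)c1)N1Cc2c(-c3ccc(F)cc3F)cnn2CC1C1CC1`: 32100 nM
compound 2 `N#CC1CC(=O)N(c2cnn3c2CN(C(=O)Nc2cc(F)c(F)c(F)c2)C(C2CC2)C3)C1`: > 200000 nM (a limit)
compound 3 `CC1CN(C(=O)Nc2cc(F)c(F)c(F)c2)Cc2c(N3CC(C#N)CC3=O)cnn21`: 115000 nM

Compound 2 reads > 200000 nM, which is a limit of the assay and not a number. Of the two true numbers, compound 3 holds the higher at 115000 nM, and compound 1 gives 32100 nM, a gap beyond the usual scatter.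

The next compound to be tested is compound 4 `CC1(C)CN(C(=O)Nc2cc(F)c(F)c(F)c2)Cc2c(N3CC(C#N)CC3=O)cnn21`. It differs from compound 3 by methyl in place of hydrogen on a saturated ring carbon.

Among the measured compounds shown here, only one measured step is available, an at least 6.2-fold higher number from compound 1 to compound 2 (0.79 log units; beyond the scatter). That step is the exchange of 2,4-difluorophenyl for 4-cyano-2-oxopyrrolidin-1-yl on an aromatic carbon, so it is a change at another place. Compound 4 keeps the 4-cyano-2-oxopyrrolidin-1-yl group of compound 3. For the measured compounds named here, no measured pair tests a methyl on this ring carbon, so the step offers only weak guidance here.

No shift beyond the scatter is therefore expected in this assay, and a reading at the limit remains possible. The expected change is a 1.1-fold lower number from compound 3 to compound 4 (0.04 log units; within the scatter). The estimate for compound 4 is 105000 nM, with an expected range of 45000 nM to 200000 nM.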

Compound 4, half-maximal cytotoxic concentration: > 200000 nM
Compound 4 was reported as a limit; the forecaster's own chance of this, stated with the estimate: 20%; middle value at least 1.9-fold (0.27 log units) from the limit.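

In this assay, among the compounds shown here, this is the first measured change at the saturated ring carbon, and methyl in place of hydrogen gives an at least 1.7-fold higher number from compound 3 to compound 4 (0.24 log units; that floor lies within the scatter). Since that floor lies within the scatter, the step sets a lower bound only and does not establish a real rise, although it does show that the added methyl brings no fall in the number at this position. Compound 4 gives > 200000 nM, which is a limit of the assay and not a number, and the series now has a second compound at that ceiling, which restricts what further changes can show in this assay: the limit of > 200000 nM in this assay, at which 2 of the 4 values shown sit.

Going by these compounds, the true size of the step remains open, as does whether the methyl would have any effect on the 2,4-difluorophenyl compound, where compound 1 leaves room for a rise to be read as a number. Also open, on these data alone, is how the number responds to a larger or charged group on this saturated ring carbon, such as an ethyl chain, an amine or a carboxylic acid.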